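The compounds below may be only part of what the source reports. "The series", "measured", "known", "first", "only" and "open" are said of these compounds alone.

The compounds share the core of compound 1, `Nc1cc(N)c2nc(-c3ccccc3)c(NCc3ccc(Cl)c(Cl)c3)nc2c1`, which in a functional assay on A498 cells (Homo sapiens) for inhibition, read by sulforhodamine B assay, with a stated time of 48 h (a higher number here means that more compound is tolerated, a lower number that less compound is tolerated), gives 60300 nM. Compound 2, `Nc1cc(N)c2nc(-c3ccccc3)c(NCc3ccc(F)cc3)nc2c1`, gives 57500 nM in this assay. Compound 3, `COc1ccc(CNc2nc3cc(N)cc(N)c3nc2-c2ccccc2)cc1`, gives in this assay only a limit of the assay, < 100000 nM. Compound 2 thus stands beside compound 1, the step of a 1.0-fold lower number from compound 1 to compound 2 (0.02 log units; within the scatter) separating the two. The steps a step that the limit leaves unreadable from compound 1 to compound 3 and a step that the limit leaves unreadable from compound 2 to compound 3 cannot be read because of the limit of < 100000 nM in this assay, at which 1 of the 3 values shown sits.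

Compound 4, `Nc1cc(N)c2nc(-c3ccccc3)c(Sc3ccc(Cl)c(Cl)c3)nc2c1`, differs from compound 2 by (3,4-dichlorophenyl)sulfanyl in place of (4-fluorobenzyl)amino on an aromatic carbon. Among the measured compounds shown here, only one readable measured step bears on this change: the swap of the aryl substituent in a 1.0-fold lower number from compound 1 to compound 2 (0.02 log units; within the scatter), which moved nothing beyond the scatter. For the measured compounds named here, no measured step touches the sulfur linker or the loss of the hydrogen-bond donor, so the expectation rests on that aryl swap alone. Compound 4 is therefore expected to give about 60000 nM in this assay, within a range from 20000 nM to 150000 nM. The step of a 1.0-fold higher number from compound 2 to compound 4 (0.02 log units; within the scatter) is expected to stay within the scatter.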

Compound 4, concentration lethal to 50% of the cells: 57500 nM
Compound 4: middle estimate off by 1.0-fold (0.02 log units), on the high side, and the stated range covers the measured number.
By their numbers in this assay, from the lowest: compounds 2, 4 and 1 (each within the scatter of the next).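

With this assay, the exchange of (4-fluorobenzyl)amino for (3,4-dichlorophenyl)sulfanyl on the aromatic carbon next to the ring nitrogen gives no change at the digits printed from compound 2 to compound 4 (within the scatter). The earlier readable step changed only the aryl substituent on the saturated chain carbon, whereas this one replaces the whole group on the aromatic carbon, including the nitrogen link, and takes the count from 1 hydrogen-bond donor to 0 hydrogen-bond donors. Even so, the two compounds cannot be told apart in this assay, so this position tolerates a sulfur-linked aryl group in place of a nitrogen-linked benzyl group without a readable change.

The compounds shown leave open whether a carboxylic acid, a simple alkyl amine or a longer chain on this carbon would move the number beyond the scatter. The steps to compound 3 cannot be read, as its value is only a limit: the limit of < 100000 nM in this assay, at which 1 of the 4 values shown sits.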